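The compounds below may be only part of what the source reports. "The series", "measured", "known", "first", "only" and "open" are said of these compounds alone.

Of the compounds shown here, two in this set have been measured, and a third has not. Compound 1, with the structure `C[C@@H](c1nc2ccc(Cl)cc2[nH]1)[C@H]1CC[C@@H](c2ccnc3ccc(F)cc32)CC1`, carries a benzimidazole-type group on the carbon chain attached to the shared core; in an assay on tissue (M109 cells) for inhibition of Indoleamine 2,3-dioxygenase 1 (Mus musculus), with stated times of 2 h and 18 h (a lower number here means a stronger inhibitor, a higher number a weaker inhibitor), compound 1 gives 12 nM. Compound 2, with the structure `C[C@@H](NS(=O)(=O)c1ccc(Cl)cc1)[C@H]1CC[C@@H](c2ccnc3ccc(F)cc32)CC1`, carries instead a (4-chlorophenyl)sulfonyl group on an amine nitrogen. In this assay compound 2 shows only > 1000 nM, which is a limit of the assay and not a number. This places compound 2 at the limit of > 1000 nM in this assay, at which 1 of the 2 values shown sits, so no finished value is known for it.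

Compound 3, with the structure `C[C@@H](NC(=O)c1cccc(Cl)c1)[C@H]1CC[C@@H](c2ccnc3ccc(F)cc32)CC1`, differs from compound 2 in one place: (3-chlorophenyl)carbonyl in place of (4-chlorophenyl)sulfonyl on an amine nitrogen. For the measured compounds named here, no measured step between these two compounds exists, so the size of the change can only be expected, not read off. Because compound 2 sits at the limit of > 1000 nM in this assay, at which 1 of the 2 values shown sits, any change toward stronger inhibition would have to take compound 3 past that limit. The expected step is beyond the usual scatter, toward stronger inhibition, which the estimate expresses as an at least 16-fold lower number from compound 2 to compound 3 (1.22 log units; beyond the scatter). For compound 3 the expected value in this assay is 60 nM, with a range from 10 nM to 500 nM.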

Compound 3, half-maximal inhibitory concentration: 48 nM
The estimate for compound 3 lay 1.3-fold (0.10 log units) above the measured number; low and high end bracket the measured number.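

Replacing (4-chlorophenyl)sulfonyl with (3-chlorophenyl)carbonyl on an amine nitrogen gives, in this assay, an at least 20-fold lower number from compound 2 to compound 3 (1.31 log units; beyond the scatter). The true size of this step cannot be read, because the value of compound 2 is a limit of the assay and not a number: the limit of > 1000 nM in this assay, at which 1 of the 3 values shown sits. Compound 2 and compound 3 both keep this amine nitrogen, so its presence alone does not rule out strong inhibition, and the group it carries can decide whether a compound gives a measured value in this assay.

This single step changes two things together, the sulfonyl link becoming a carbonyl link and the chlorine moving from the 4-position of the phenyl ring to the 3-position, so the compounds shown cannot say which of the two accounts for the difference. A (4-chlorophenyl)carbonyl or a (3-chlorophenyl)sulfonyl group on the same nitrogen would separate these two changes, while an unsubstituted phenylcarbonyl group would test whether the chlorine is needed at all.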